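The source may report more compounds than this note shows. Statements on the series, on what has been measured and on what is new or still open speak of the compounds shown alone.

Three related compounds have been tested: compound 1 `O=C(/C=C/c1ccc(O)cc1)Nc1cc2c(Nc3ccc(Cl)c(Cl)c3)ncnc2s1`, compound 2 `O=C(/C=C/c1ccccc1)Nc1cc2c(Nc3ccc(F)c(Cl)c3)ncnc2s1` and compound 3 `COc1ccc(/C=C/C(=O)Nc2cc3c(Nc4cc(Cl)cc(Cl)c4)ncnc3s2)cc1`. In a functional assay on MCF7 cells (Homo sapiens) for antiproliferative activity, read by MTT assay, with a stated time of 48 h (on this read-out lower numbers stand for stronger inhibition and higher numbers for weaker inhibition), compound 1 gives 60600 nM and compound 3 gives 75600 nM, two values within the usual scatter of each other. Compound 2 gives 14300 nM, the lowest number of the three and beyond the scatter from both others, which makes it the most potent of this small set. These compounds differ in more than one place, so they do not isolate the effect of any single change.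

Compound 4 `C#Cc1cccc(Nc2ncnc3sc(NC(=O)/C=C/c4ccccc4)cc23)c1` has not yet been measured. It differs from compound 2 in one place: 3-ethynylphenyl in place of 3-chloro-4-fluorophenyl on a nitrogen on an aromatic ring. In words, this is 3-ethynylphenyl in place of 3-chloro-4-fluorophenyl on a nitrogen on an aromatic ring. Within the data shown here, no measured pair shows this swap, so only a small shift toward weaker inhibition in this assay is expected, starting from the 14300 nM of compound 2. The estimated change is a 1.4-fold higher number from compound 2 to compound 4 (0.15 log units; within the scatter). For compound 4 the estimated value is 20000 nM, with an expected range from 7000 nM to 60000 nM.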

Compound 4, half-maximal inhibitory concentration: 38400 nM
Compound 4: the middle estimate sits 1.9-fold (0.28 log units) below what was measured, within the range that was stated.
By their numbers in this assay, from the lowest: compound 2; then compounds 4, 1 and 3 (each within the scatter of the next).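

Among these compounds, the first comparison in this set that changes only one place concerns the aromatic ring on the nitrogen: in this assay, putting 3-ethynylphenyl in place of 3-chloro-4-fluorophenyl gives a 2.7-fold higher number from compound 2 to compound 4 (0.43 log units; beyond the scatter). This step is modest but beyond the scatter, so activity responds to the group at this position, and 3-chloro-4-fluorophenyl is the better of these two, even though both groups have the same heavy-atom count and neither has hydrogen-bond donors or acceptors. No accompanying measurement explains this difference.

A single step cannot separate the contributions of losing the chlorine, losing the fluorine and gaining the ethynyl group. The compounds shown also leave open how a nitrile or an amine on this ring would compare.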